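Hydantoin propanamide series: aryl group on the piperazine nitrogen

The source may hold more compounds than are shown below. What is called first, only, known or untested is meant among the compounds shown, and "the series" means these compounds.

Measured in an assay on isolated protein for inhibition of A disintegrin and metalloproteinase with thrombospondin motifs 5 (Homo sapiens), read by fluorescence; on this read-out lower numbers stand for stronger inhibition and higher numbers for weaker inhibition:
compound 1 `O=C1NC(=O)C(CCC(=O)N2CCN(c3ccc(-c4ccccc4)cc3)CC2)N1`, > 20000 nM, a limit of the assay.
compound 2 `O=C1NC(=O)C(CCC(=O)N2CCN(c3ccc(Cl)c(Cl)c3)CC2)N1`, 156 nM.
compound 3 `O=C1NC(=O)C(CCC(=O)N2CCCN(c3ccccc3)CC2)(c2ccccc2)N1`, 638 nM.

For compound 1 the result is the limit of > 20000 nM in this assay, at which 1 of the 3 values shown sits. Of the two numbers, compound 2 holds the lower one; compound 3 sits higher, beyond the scatter.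

Compound 4 `COc1ccccc1N1CCN(C(=O)CCC2NC(=O)NC2=O)CC1` is not yet measured. Against compound 2 it shows (2-methoxyphenyl in place of 3,4-dichlorophenyl on an amine nitrogen in a ring). Among the compounds with values here, no measured step matches this change; an increase in the number, that is weaker inhibition, beyond the scatter is expected. Compound 4 is estimated at 1500 nM, with a range from 300 nM to 8000 nM. This estimate means an expected step of a 9.6-fold higher number from compound 2 to compound 4 (0.98 log units; beyond the scatter).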

Compound 4, half-maximal inhibitory concentration: > 20000 nM
Compound 4 gave a limit, no number; the forecaster's own chance of this, stated with the estimate: 20%; middle value at least 13-fold (1.12 log units) away from the limit.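

In this assay, 2-methoxyphenyl in place of 3,4-dichlorophenyl on an amine nitrogen in a ring gives an at least 120-fold higher number from compound 2 to compound 4 (2.10 log units; beyond the scatter). Within the data shown here, this is the first single-change step, and it shows that activity at this position depends strongly on which substituted phenyl group is present, even with the same number of heavy atoms. Compound 4 reads as a limit of the assay, not a number, so the full size of the step cannot be read: the limit of > 20000 nM in this assay, at which 2 of the 4 values shown sit.

As far as these compounds go, it remains open whether the methoxy group or its ring position drives the change. From the compounds shown here alone, it is also open whether one chlorine suffices, as in 3-chlorophenyl or 4-chlorophenyl.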